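A Methyl for a Methoxy, Tested Once More

The source may report more compounds than this note shows. Statements on the series, on what has been measured and on what is new or still open speak of the compounds shown alone.

Two small compounds open the set. Compound 1 `Cc1ccc(-c2cc(/N=C3/NC(=O)CS3)cs2)cc1` and compound 2 `COc1ccc(-c2cc(/N=C3/NC(=O)CS3)cs2)cc1` share a core and differ in a single group. In a functional assay on MDA-MB-231 cells (Homo sapiens) for cytotoxicity, read by MTT assay, with a stated time of 72 h (a lower number here means a stronger inhibitor, a higher number a weaker inhibitor), compound 1 gives > 50000 nM, which is a limit of the assay and not a number. In this assay compound 2 gives > 50000 nM, again a limit. Both therefore sit at the limit of > 50000 nM in this assay, at which 2 of the 3 values shown sit, so the step that the two limits leave unreadable from compound 2 to compound 1 cannot be sized; the change itself is methyl in place of methoxy on an aromatic carbon.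

Compound 3 `COc1ccc(/C=C2\S/C(=N\c3csc(-c4ccc(Cl)cc4)c3)NC2=O)cc1` carries a larger core; how it differs from compound 2 is not broken down here. In this assay, going by the values given here, compound 3 gives 1200 nM, the only number in the set. Compound 4 `Cc1ccc(/C=C2\S/C(=N\c3csc(-c4ccc(Cl)cc4)c3)NC2=O)cc1` is compound 3 with the same change, (methyl in place of methoxy on an aromatic carbon), and the place is described in the same words, so this is the same change made a second time. Among the compounds with values here, its one measured instance, from compound 2 to compound 1, sits between two limits and lends no size. The step from compound 3 to compound 4 is expected to be about a 1.7-fold higher number from compound 3 to compound 4 (0.22 log units; within the scatter), resting only on the unreadable step that the two limits leave unreadable from compound 2 to compound 1. Compound 4 is estimated to come in near 2000 nM, between 600 nM and 7000 nM.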

Compound 4, half-maximal inhibitory concentration: 900 nM
Compound 4: the middle estimate sits 2.2-fold (0.35 log units) above what was measured; the range from low to high includes it.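

In this assay the change from 4-methoxyphenyl to 4-methylphenyl on the larger core gives a 1.3-fold lower number from compound 3 to compound 4 (0.12 log units; within the scatter) and so cannot be told apart from the ordinary spread of repeated measurements. This is one readable instance on one core, which shows that the swap was tolerated there but does not establish a rule that holds from core to core. The smaller core offers nothing to set beside it, and the two cores cannot be said to agree or disagree, because compound 1 and compound 2 each give only a limit of the assay and not a number: the limit of > 50000 nM in this assay, at which 2 of the 4 values shown sit.

Methyl and methoxy are the only two groups compared in this place, so it remains open whether an amine, a carboxylic acid or a longer chain such as ethoxy would give a step beyond the scatter. From the compounds shown here alone, it also remains open whether a third core would respond to the methyl-for-methoxy change as the core of compound 3 does.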